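A Methoxyphenyl Swap on a Weakly Cytotoxic Triazole

The source may report more compounds than this note shows. Statements on the series, on what has been measured and on what is new or still open speak of the compounds shown alone.

Compound 1 `O=C1O/C(=C\Cn2cc(-c3cc(F)cc(F)c3)nn2)C(OCc2ccccc2)=C1OCc1ccccc1` is examined in an ADME assay on HFF cells (Homo sapiens) for cytotoxicity, read by MTT assay, with a stated time of 72 h; on this read-out lower numbers stand for stronger inhibition and higher numbers for weaker inhibition. In this assay compound 1 gives > 100000 nM, which is a limit of the assay and not a number. Where compound 1 stands among the measured compounds is therefore known only as a bound. Two compounds with a different linkage between the shared core and the triazole serve as reference points: compound 2 `CC(C)(C)OC(=O)N1CCN(C(=S)SCc2cn(C[C@H](O)[C@H]3OC(=O)C(OCc4ccccc4)=C3OCc3ccccc3)nn2)CC1` gives 60 nM in this assay, and compound 3 `CC(C)(C)c1cn(C[C@H](O)[C@H]2OC(=O)C(OCc3ccccc3)=C2OCc2ccccc2)nn1` gives 13300 nM. Among the measured compounds shown here, no step between two measured compounds that differ in a single place is available, so the effect of an aryl exchange on this scaffold has not been measured. Compound 4 `COc1ccccc1-c1cn(C/C=C2\OC(=O)C(OCc3ccccc3)=C2OCc2ccccc2)nn1` differs from compound 1 in one place: 2-methoxyphenyl in place of 3,5-difluorophenyl on an aromatic carbon. Since compound 1 sits at the limit of > 100000 nM in this assay, at which 1 of the 3 values shown sits, any step from it cannot be located precisely; the change is expected to be small or to lie within the scatter, with compound 4 most likely again close to the limit. The step of an at least 1.2-fold lower number from compound 1 to compound 4 (0.09 log units; that floor lies within the scatter) is an expectation only. For compound 4 the estimated value is 80000 nM, in a range from 20000 nM to 300000 nM.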

Compound 4, half-maximal inhibitory concentration: > 100000 nM
Compound 4: a limit, no number (the forecaster's own chance of this, stated with the estimate: 55%); middle value at least 1.2-fold (0.09 log units) away from the limit.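

In this assay compound 4 gives > 100000 nM, which is a limit of the assay and not a number. Among the compounds shown here, compound 1 also stands at a limit, so no step between compound 1 and compound 4 can be read. The compounds shown leave open whether 2-methoxyphenyl in place of 3,5-difluorophenyl changes the cytotoxicity at all.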